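Amide nitrogen substitution in the oxalamide series

The source may report more compounds than this note shows. Statements on the series, on what has been measured and on what is new or still open speak of the compounds shown alone.

Compound 1 `O=C(CCc1ccc(Cl)cc1)C(=O)NCCCCc1ccccc1` gives 200 nM in an assay on HEK-293T cells for inhibition of phospholipase A and acyltransferase 5 (Homo sapiens), with stated times of 30 min and 20 min; a higher number here means a weaker inhibitor, a lower number a stronger inhibitor. Compound 3 `CCNC(=O)C(=O)CCc1ccc(Cl)cc1` gives 1000 nM in this assay. Compound 2 `O=C(NCc1ccccc1)C(F)(F)C(O)CCc1ccccc1` returns only a limit, > 10000 nM, which is the limit of > 10000 nM in this assay, at which 1 of the 3 values shown sits. Among the two numbers shown, compound 3 stands highest; its nearest neighbour is compound 1, and the step of a 5.0-fold higher number from compound 1 to compound 3 (0.70 log units; beyond the scatter) lies beyond the scatter.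

Compound 4 `CN(C)C(=O)C(=O)CCc1ccc(Cl)cc1` differs from compound 3 by dimethylamino in place of ethylamino on a carbonyl carbon. Among the compounds with values here, the one measured step, a 5.0-fold higher number from compound 1 to compound 3 (0.70 log units; beyond the scatter), alters the chain on the amide-type nitrogen but keeps the amide hydrogen, so it does not cover the change at hand; compound 2 also carries an amide hydrogen but yields only a limit. Within the data shown here, no measured step therefore speaks directly to the removal of the amide hydrogen, and the direction of the step in this assay is open. A weakening beyond the scatter is expected as the likelier outcome, though with wide uncertainty: compound 4 is estimated at 2500 nM, between 700 nM and 10000 nM. This estimate means a step of a 2.5-fold higher number from compound 3 to compound 4 (0.40 log units; beyond the scatter) that is expected rather than known.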

Compound 4, half-maximal inhibitory concentration: > 10000 nM
Compound 4: a limit, no number; the forecaster's own chance of this, stated with the estimate: 25%; at least 4.0-fold (0.60 log units) between middle value and limit.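

Within the data shown here, the step of an at least 10-fold higher number from compound 3 to compound 4 (1.00 log units; beyond the scatter) is the first measured change that takes away the amide hydrogen, and the atoms stay the same but are joined differently. By contrast, a 5.0-fold higher number from compound 1 to compound 3 (0.70 log units; beyond the scatter) alters the chain on the amide-type nitrogen and keeps that hydrogen, so only the new step shows that dimethylamino on this carbonyl carbon is poorly tolerated in this assay. Compound 4 gives only a limit, > 10000 nM, so the step has a lower bound and no measured size: the limit of > 10000 nM in this assay, at which 2 of the 4 values shown sit.

Open, going by these compounds, is whether the loss follows the missing amide hydrogen alone or also the second carbon on the nitrogen, a question that a methylamino group on the same carbonyl carbon would address. Also open, on these data alone, is whether a dimethylamino-type change would cost as much on the longer chain of compound 1.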